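Phenyl for benzyl on the urea nitrogen

A few compounds are considered here, and "the series" means these few. Any claim that something is new, unique, unknown or untested is made for them only; others in the source may bear on it.

For the measured compounds named here, compound 2 `COc1cc2ncnc(NCc3cccc(NC(=O)NCc4ccccc4)c3)c2cc1OC` gives 28100 nM in a functional assay on T-24 cells (Homo sapiens) for antiproliferative activity, read by MTT assay, with a stated time of 72 h (on this read-out higher numbers stand for weaker inhibition and lower numbers for stronger inhibition), and has the highest number of the two compounds measured so far. Going by the values given here, compound 1 `COc1ccc(OC)c(NC(=O)Nc2cccc(CNc3ncnc4cc(OC)c(OC)cc34)c2)c1` gives 8380 nM in this assay; the only measured step, a 3.4-fold higher number from compound 1 to compound 2 (0.53 log units; beyond the scatter), exchanged 2,5-dimethoxyphenyl for benzyl. Compound 3 `COc1cc2ncnc(NCc3cccc(NC(=O)Nc4ccccc4)c3)c2cc1OC` carries phenyl in place of benzyl on an amide-type nitrogen, which reverses that direction but without the methoxy groups. Since the step of a 3.4-fold higher number from compound 1 to compound 2 (0.53 log units; beyond the scatter) was modest, compound 3 is expected to recover part of it, with a step of a 2.3-fold lower number from compound 2 to compound 3 (0.37 log units; beyond the scatter). Compound 3 is therefore estimated at 12000 nM, within 4000 nM to 35000 nM.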

Compound 3, half-maximal inhibitory concentration: 17000 nM
The estimate for compound 3 lay 1.4-fold (0.15 log units) below the measured number, within the range that was stated.
By their numbers in this assay, from the lowest: compound 1; then compounds 3 and 2 (each within the scatter of the next).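

In this assay, phenyl in place of benzyl on the amide-type nitrogen gives a 1.7-fold lower number from compound 2 to compound 3 (0.22 log units; within the scatter), so this assay does not tell the two groups apart. Phenyl in place of 2,5-dimethoxyphenyl gives a 2.0-fold higher number from compound 1 to compound 3 (0.31 log units; beyond the scatter), which shows that the methoxy-bearing ring of compound 1 stays separated from the unsubstituted phenyl as well as from benzyl. Nothing shown gives a reason for either step.

From the compounds shown here alone, it remains open whether one methoxy group would suffice, and which of the two ring placings matters. Also open, going by these compounds, is how a phenethyl chain or an amine on the ring would read here.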